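A few compounds are considered here, and "the series" means these few. Any claim that something is new, unique, unknown or untested is made for them only; others in the source may bear on it.

Measured in an ADME assay on Vero cells (Chlorocebus sabaeus) for cytotoxicity; a higher number here means that more compound is tolerated, a lower number that less compound is tolerated:
Compound 1 `CC(C)CCNc1nc(Nc2cccc(O)c2)c2nc[nH]c2n1`: 151000 nM
Compound 2 `OCCNc1nc(Nc2cccc(O)c2)c2nc[nH]c2n1`: > 175000 nM (a limit of the assay)

Compound 2 has no exact number. Its reading of > 175000 nM is a limit and not a measured value. It stands at the limit of > 175000 nM in this assay, at which 1 of the 2 values shown sits.

The next compound is compound 3 `CNc1nc(Nc2cccc(O)c2)c2nc[nH]c2n1`, which has hydrogen in place of hydroxymethyl on a saturated chain carbon bound to a nitrogen on an aromatic ring. Cut one bond further out, the same difference reads 2-hydroxyethyl to methyl.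

Among the measured compounds shown here, only one measured step bears on this change, and it also alters the saturated chain: an at least 1.1-fold higher number from compound 1 to compound 2 (0.06 log units; that floor lies within the scatter). Replacing isopropyl with hydroxy on that chain therefore gave no shift that can be told from the scatter, so no step beyond the scatter is expected in this assay, and no direction can be assigned. Compound 3 may well reach the same limit. The expected change is an at least 1.0-fold lower number from compound 2 to compound 3 (0.01 log units; that floor lies within the scatter). The estimate for compound 3 is 170000 nM, with an expected range from 90000 nM to 320000 nM.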

Compound 3, half-maximal cytotoxic concentration: 168000 nM
Estimate against measurement, compound 3: 1.0-fold (0.01 log units) above, within the range that was stated.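

In this assay, hydrogen in place of isobutyl on a saturated chain carbon bound to a nitrogen on an aromatic ring gives a 1.1-fold higher number from compound 1 to compound 3 (0.05 log units; within the scatter), so a comparison of two exact readings now shows that this change at this position cannot be told from the scatter, which the earlier step, resting on a limit, could not show. Hydrogen in place of hydroxymethyl at the same place gives an at least 1.0-fold lower number from compound 2 to compound 3 (0.01 log units; that floor lies within the scatter), so this step, like the earlier one, offers no floor beyond the scatter and assigns no direction to the loss of the hydroxymethyl group. The reading for compound 2 is a limit of the assay and not a number, so its true distance from the other two compounds stays unknown: the limit of > 175000 nM in this assay, at which 1 of the 3 values shown sits.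

The compounds shown leave open how far the true value of compound 2 lies past that limit, and so whether the 2-hydroxyethyl chain differs at all from methyl. They also leave open whether a carboxylic acid, an amine or a ring carried on this chain would give a step beyond the scatter in this assay.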